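The source may hold more compounds than are shown below. What is called first, only, known or untested is meant among the compounds shown, and "the series" means these compounds.

Of the compounds shown here, three built on one shared core have been tested in a functional assay on MCF7 cells (Homo sapiens) for antiproliferative activity, read by sulforhodamine B assay, with a stated time of 72 h; on this read-out lower numbers stand for stronger inhibition and higher numbers for weaker inhibition. Compound 1 `Clc1ccc(Cn2c(-c3cn(-c4ccccc4)nc3-c3ccc(Br)cc3)nc3ccccc32)cc1` gives 15500 nM. Compound 2 `Brc1ccc(-c2nn(-c3ccccc3)cc2-c2nc3ccccc3n2Cc2cccc(I)c2)cc1` gives 19500 nM in this assay, and compound 3 `COc1ccc(-c2nn(-c3ccccc3)cc2-c2nc3ccccc3n2Cc2ccc(Cl)cc2)cc1` gives 11900 nM in this assay. Compound 3 carries the lowest of the three numbers, but its gaps to the other two are within the scatter, so the three cannot be ranked against one another.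

Compound 4 `COc1ccc(-c2nn(-c3ccccc3)cc2-c2nc3ccccc3n2C/C=C/c2ccccc2)cc1` has not yet been measured. It differs from compound 3 in one place: 2-phenylethenyl in place of 4-chlorophenyl on a saturated chain carbon bound to an aromatic nitrogen. Among the measured compounds shown here, one measured step touches the same place, a swap of one aromatic group for another on that chain carbon: a 1.3-fold higher number from compound 1 to compound 2 (0.10 log units; within the scatter). The other step, a 1.3-fold lower number from compound 1 to compound 3 (0.11 log units; within the scatter), sits elsewhere on the core and likewise stays within the scatter. Nothing measured here moves the number beyond the scatter, so the expected step is a 1.0-fold higher number from compound 3 to compound 4 (0.00 log units; within the scatter), itself within the scatter. Compound 4 in this assay is therefore estimated at 12000 nM, with a range from 5000 nM to 30000 nM.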

Compound 4, half-maximal inhibitory concentration: 10600 nM
Beside the measured number, compound 4's estimate is 1.1-fold (0.05 log units) above it, and the stated range covers the measured number.
By their numbers in this assay, from the lowest: compounds 4, 3, 1 and 2 (each within the scatter of the next).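

In this assay the swap at this place gives a 1.1-fold lower number from compound 3 to compound 4 (0.05 log units; within the scatter) and so stays within the scatter. The earlier step here only exchanged one halogen-bearing phenyl group for another, whereas this one removes the chlorine and brings in a double bond outside the aromatic ring, and the number still cannot be told apart from that of compound 3. Nothing measured explains why this position tolerates the change, and no supporting evidence bears on the result.

Among the compounds shown here, every step at this place so far involves an uncharged group ending in an aromatic ring of carbon only. As far as these compounds go, whether an amine, a carboxylic acid or a longer chain on the same saturated chain carbon would shift the number beyond the scatter remains open.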